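Working notes: a carboxylic acid pair and a nitro analogue

The compounds below may be only part of what the source reports. "The series", "measured", "known", "first", "only" and "open" are said of these compounds alone.

Compound 1 `CCOC(=O)C1=Cc2ccccc2OC1(OCc1cc(-c2ccc(C)cc2)no1)C(F)(F)F`; in a functional assay on MCF7 cells (Homo sapiens) for inhibition, read by MTT assay, with a stated time of 24 h (a higher number here means a weaker inhibitor, a lower number a stronger inhibitor), compound 1 reaches only a limit, > 150000 nM.
Compound 2 `Cc1ccc(-c2cc(COC3(C(F)(F)F)Oc4ccccc4C=C3C(=O)O)on2)cc1`; in this assay compound 2 gives 30100 nM.

Among the compounds with values here, compound 2 holds the only number in this assay. The value of compound 1 is a limit. Within the data shown here, the one measured step, an at least 4.9-fold lower number from compound 1 to compound 2 (0.69 log units; beyond the scatter), concerns the ester and not the aryl ring. Compound 3 `O=C(O)C1=Cc2ccccc2OC1(OCc1cc(-c2ccc([N+](=O)[O-])cc2)no1)C(F)(F)F` differs from compound 2 by nitro in place of methyl on an aromatic carbon. Among the measured compounds shown here, no measured step touches that ring, so no step beyond the scatter is expected, the estimated step being a 1.0-fold lower number from compound 2 to compound 3 (0.00 log units; within the scatter). Compound 3 is estimated at 30000 nM, with a range of 9000 nM to 100000 nM.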

Compound 3, half-maximal inhibitory concentration: > 150000 nM
Compound 3 ended at the assay's limit; the forecaster's own chance of this, stated with the estimate: 20%; at least 5.0-fold (0.69 log units) between middle value and limit.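

The 4-methylphenyl ring, untouched by the earlier step, matters in this assay: nitro in place of methyl gives an at least 4.9-fold higher number from compound 2 to compound 3 (0.69 log units; beyond the scatter). The carboxylic acid alone therefore does not secure a measurable number, as compound 3 carries it too. The value of compound 3 is a limit, so the step has only a lower bound: the limit of > 150000 nM in this assay, at which 2 of the 3 values shown sit.

Only methyl and nitro are shown on this ring, so it stays open whether the change follows nitro specifically or any replacement of methyl. An amine or a chlorine at this place would begin to separate the two.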